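Nitroimidazooxazines: Vero cell toxicity and an aryl replacement

The compounds below may be only part of what the source reports. "The series", "measured", "known", "first", "only" and "open" are said of these compounds alone.

The series shares a nitroimidazooxazine core carried on three bicyclic amines. Compound 1 `C[C@]1(CN2CCc3nc(-c4ccc(F)c(F)c4)oc3C2)Cn2cc([N+](=O)[O-])nc2O1` bears a difluorophenyl oxazole, compound 2 `C[C@]1(CN2CCn3cc(-c4ccc(F)cc4)nc3C2)Cn2cc([N+](=O)[O-])nc2O1` a fluorophenyl imidazole, and compound 3 `C[C@]1(CN2CCc3nc(C(F)(F)F)ccc3C2)Cn2cc([N+](=O)[O-])nc2O1` a trifluoromethyl group. In an ADME assay on Vero cells (Chlorocebus sabaeus) for cytotoxicity, read by MTT assay, with a stated time of 72 h (on this read-out higher numbers stand for lower toxicity in this test and lower numbers for higher toxicity in this test), compound 1 gives only a limit, > 32 ug/mL, and no number. For compound 2 the result in this assay is "not determined" (no result reported), meaning no result was reported. Compound 3 stands without any value either: in this assay it is recorded as "not determined" (no result reported). Within the data shown here, the only guide is therefore (the limit of > 32 ug/mL in this assay, at which 1 of the 3 values shown sits).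

Compound 4 `C[C@]1(CN2CCc3nc(-c4ccc(Cl)c(F)c4)ccc3C2)Cn2cc([N+](=O)[O-])nc2O1` differs from compound 3 by 4-chloro-3-fluorophenyl in place of trifluoromethyl on an aromatic carbon. Among the measured compounds shown here, with no measured step in hand, the size of the change cannot be judged; compound 4 is expected to sit near the limit, estimated at 32 ug/mL with a range from 12 ug/mL to 64 ug/mL.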

Compound 4, half-maximal cytotoxic concentration: > 32 ug/mL
Compound 4 ended at the assay's limit (the forecaster's own chance of this, stated with the estimate: 65%); the middle value lies on the limit itself.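

Compound 3 has no reported result and compound 4 gives only a limit in this assay, so no step can be read between them. The compounds shown leave open the actual values of compound 1 and compound 4, for which the only guide is a shared limit: the limit of > 32 ug/mL in this assay, at which 2 of the 4 values shown sit.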